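This account rests on a few compounds, and the source may have more. Where it says the series, first, only, none or still open, it means among the compounds named here.

In an ADME assay on Vero cells (Chlorocebus sabaeus) for cytotoxicity, read by resazurin assay, with a stated time of 72 h (a lower number here means a stronger inhibitor, a higher number a weaker inhibitor), two compounds sharing one core have readings so far. Compound 1 (`O=C(CCN1CCN(c2ccc(Cl)cc2)CC1)c1ccc(C(F)(F)F)cc1`) gives 54200 nM as its half-maximal inhibitory concentration, and compound 2 (`O=C(CCN1CCN(c2ccc([N+](=O)[O-])cc2)CC1)c1ccc(C(F)(F)F)cc1`) gives 75700 nM on the same read-out, so compound 2 stands level with compound 1. Going by the values given here, the only measured step (a 1.4-fold higher number from compound 1 to compound 2 (0.15 log units; within the scatter)) is nitro in place of chloro on an aromatic carbon.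

Compound 3 (`O=C(CCN1CCN(c2ccc([N+](=O)[O-])cc2)CC1)c1ccc(OC(F)(F)F)cc1`) keeps the nitro group of compound 2, and its change is trifluoromethoxy in place of trifluoromethyl on an aromatic carbon. Among the compounds with values here, no measured step alters the trifluoromethyl group, so the one step available bears on this change only indirectly, as a single substituent swap in this small set that stayed within the scatter. No step beyond the scatter is therefore expected in this assay, and no direction can be named. The estimated step (a 1.1-fold lower number from compound 2 to compound 3 (0.02 log units; within the scatter)) is expected to be small. Compound 3 is estimated at 72000 nM with an expected range of 38000 nM to 135000 nM on this read-out.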

Compound 3, half-maximal inhibitory concentration: 93200 nM
For compound 3 the middle estimate is 1.3-fold (0.11 log units) below the measured one, within the range that was stated.
By their numbers in this assay, from the lowest: compounds 1, 2 and 3 (each within the scatter of the next).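

Going by these compounds alone, this is the first reading of a change at the trifluoromethyl position, on an aromatic carbon para to a large group, since the earlier step touched only the substituent at the other end of the molecule. In this assay, the swap to trifluoromethoxy, which brings in one oxygen and one hydrogen-bond acceptor, gives a 1.2-fold higher number from compound 2 to compound 3 (0.09 log units; within the scatter), so this change has no readable effect on the number when the nitro group is held fixed, and a single substituent swap at each of the two sites has now stayed within the scatter. No measurement available here offers an explanation for this result.

The compounds shown leave open whether a group of a different kind at this position, such as an amine or a carboxylic acid, would move the number beyond the scatter. They also leave open whether the same swap would read alike with chloro in place of nitro, and whether a longer chain between the carbonyl and the shared core's other ring would change the picture.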